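A few compounds are considered here, and "the series" means these few. Any claim that something is new, unique, unknown or untested is made for them only; others in the source may bear on it.

Among the measured compounds shown here, in a physicochemical assay for lipophilicity (on this read-out lower numbers stand for lower lipophilicity and higher numbers for higher lipophilicity), compound 2 `CS(=O)(=O)c1ccc(O)c(C(=O)Nc2ccc(C(F)(F)F)cc2)c1` gives 1.48, the lower of the two numbers measured so far, while compound 1 `CCCCCCCCCCCCS(=O)(=O)c1ccc(O)c(C(=O)Nc2ccc(C(F)(F)F)cc2)c1` gives 6.2. Compound 3 `CCCCCCCCCCS(=O)(=O)c1ccc(O)c(C(=O)Nc2ccc(C(F)(F)F)cc2)c1` has not yet been measured. It carries nonyl in place of hydrogen on a saturated chain carbon bound to a sulfonyl sulfur. For the measured compounds named here, only one measured step bears on this change: a number 4.72 log units lower from compound 1 to compound 2 (beyond the scatter), large and beyond the scatter, with hydrogen in place of undecyl at that same place. Nonyl is a shorter chain than undecyl, so the number is expected to rise well beyond the scatter, yet by less than the size of that step. Two compounds cannot show how evenly the number follows chain length, so the range is kept wide. The expected change is a number 3.82 log units higher from compound 2 to compound 3 (beyond the scatter). Compound 3 is therefore estimated at 5.3, within an expected range of 4.7 to 5.8.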

Compound 3, distribution coefficient: 6.34
The estimate for compound 3 lay 1.04 log units below the measured number; measured number outside the range, above it.
By their numbers in this assay, from the lowest: compound 2; then compounds 1 and 3 (each within the scatter of the next).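

In this assay, nonyl in place of hydrogen on a saturated chain carbon bound to a sulfonyl sulfur gives a large change (a number 4.86 log units higher from compound 2 to compound 3 (beyond the scatter)). Adding ethyl further out on the chain does not separate the compounds, as hydrogen in place of ethyl on a saturated chain carbon stays within the scatter (a number 0.14 log units higher from compound 1 to compound 3 (within the scatter)), so among these three compounds the number does not follow chain length evenly, with compound 1 and compound 3 going against any steady rise. Nothing measured accounts for this result.

The compounds shown leave open how the number runs through shorter chains such as butyl or hexyl, and whether a longer chain would depart from it. They also leave open what a chain ending in an amine or a carboxylic acid would give at this place.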